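This account rests on a few compounds, and the source may have more. Where it says the series, first, only, none or still open, it means among the compounds named here.

Measured compounds:
- compound 1, `Oc1cccc(-c2cc(-c3cccc(C(F)(F)F)c3)cc(-c3ccccc3O)n2)c1`, in a functional assay on DU-145 cells (Homo sapiens) for inhibition (on this read-out lower numbers stand for stronger inhibition and higher numbers for weaker inhibition), gives 13000 nM
- compound 2, `Oc1cccc(-c2cc(-c3cccc(OC(F)(F)F)c3)cc(-c3ccccc3O)n2)c1`, in this assay reaches only the limit > 50000 nM

Compound 2 stands at the weak end of what was measured: its result is a limit of the assay and not a number, (the limit of > 50000 nM in this assay, at which 1 of the 2 values shown sits). Within the data shown here, the one step that was measured, an at least 3.8-fold higher number from compound 1 to compound 2 (0.58 log units; beyond the scatter), concerns a change on a different ring, so it does not speak directly to the change now considered, but it shows that the shared core carrying a trifluoromethoxy group sits at or past the limit.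

Compound 3, `Oc1ccc(-c2cc(-c3cccc(OC(F)(F)F)c3)cc(-c3cccc(O)c3)n2)cc1`, differs from compound 2 in one place: 4-hydroxyphenyl in place of 2-hydroxyphenyl on an aromatic carbon. Among the measured compounds shown here, no measured pair tells how moving the hydroxyl on that ring affects this assay, so no direction beyond the scatter can be derived from the data. Starting from a limit, compound 3 is expected to remain around that limit, with the step that the limit leaves unreadable from compound 2 to compound 3 treated as within the scatter. For compound 3 the estimate is 60000 nM, with a range from 20000 nM to 200000 nM, and a good chance that again only a limit is reported.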

Compound 3, half-maximal inhibitory concentration: 5670 nM
For compound 3 the middle estimate is 11-fold (1.02 log units) above the measured one; measured number below the stated range.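

In this assay, swapping the 2-hydroxyphenyl for the 4-hydroxyphenyl on the aromatic carbon next to the ring nitrogen gives an at least 8.8-fold lower number from compound 2 to compound 3 (0.94 log units; beyond the scatter). Among these compounds, the two groups have the same atoms and the same counts of hydrogen-bond donors and acceptors, so this position responds to where the hydroxyl sits on the ring, something no earlier pair could show. The trifluoromethoxy group also does not rule out a measurable result, since compound 3 carries it and gives a real number, 5670 nM. The full size of the step cannot be read, because compound 2 has a limit and not a number: the limit of > 50000 nM in this assay, at which 1 of the 3 values shown sits.

On these data alone, whether the hydroxyl itself matters at this position, or only its location, stays open; a plain phenyl, a 4-methoxyphenyl or a 4-aminophenyl group there would help to separate the two, and a 3-hydroxyphenyl group would fill in the remaining ring position. As far as these compounds go, it also stays open whether the same swap has a similar effect on the core of compound 1, which carries trifluoromethyl in place of trifluoromethoxy.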